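The source may hold more compounds than are shown below. What is called first, only, known or untested is meant among the compounds shown, and "the series" means these compounds.

Of the compounds shown here, three built on one shared core have been tested in a functional assay on HepG2 cells (Homo sapiens) for antiproliferative activity, read by MTT assay, with a stated time of 24 h; on this read-out higher numbers stand for weaker inhibition and lower numbers for stronger inhibition. Compound 1 `Cc1ccccc1-n1cc(-c2ccccc2NS(=O)(=O)c2c[nH]c(=O)[nH]c2=O)nn1` gives 13900 nM in this assay, compound 2 `O=c1[nH]cc(S(=O)(=O)Nc2ccccc2-c2cn(-c3cccc(Cl)c3)nn2)c(=O)[nH]1` gives 2460 nM, and compound 3 `O=c1[nH]cc(S(=O)(=O)Nc2cccc(-c3cn(-c4ccccc4)nn3)c2)c(=O)[nH]1` gives 11200 nM. Among these three numbers compound 3 stands second highest: its value and that of compound 1 lie within the scatter of each other, while compound 2 sits clearly apart with a lower number. Among the compounds with values here, the only single change measured so far is a 5.7-fold lower number from compound 1 to compound 2 (0.75 log units; beyond the scatter), which exchanges the group carried by the aromatic nitrogen; it concerns a different part of the molecule than the change considered here. Compound 4 `Cc1ccc(-n2cc(-c3cccc(NS(=O)(=O)c4c[nH]c(=O)[nH]c4=O)c3)nn2)cc1` differs from compound 3 by methyl in place of hydrogen on an aromatic carbon. Within the data shown here, no measured step tests a methyl at this place, so the comparison of compound 1 with compound 2 shows only that altering a ring substituent can shift the number noticeably, without saying which way a methyl here would move it. Therefore only a small step is expected, a 1.2-fold lower number from compound 3 to compound 4 (0.09 log units; within the scatter). Compound 4 is estimated at 9000 nM, with a range from 3000 nM to 27000 nM.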

Compound 4, half-maximal inhibitory concentration: > 20000 nM
Compound 4: no number, only a limit; the forecaster's own chance of this, stated with the estimate: 5%; middle value at least 2.2-fold (0.34 log units) from the limit.
By their numbers in this assay, from the lowest: compound 2; then compounds 3 and 1 (each within the scatter of the next). At a limit, above all of these: compound 4.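

The change from phenyl to 4-methylphenyl is the only case shown of a methyl on an aromatic carbon para to a large group, and in this assay it gives an at least 1.7-fold higher number from compound 3 to compound 4 (0.25 log units; that floor lies within the scatter). For compound 4 there is a limit and not a number: > 20000 nM. Within the data shown here, the methyl at this place therefore brings no lower number, which the earlier compounds could not show, but the floor of the step stays within the scatter, so the result cannot be called a clear loss, and the one firm reading is that compound 4 alone sits at this limit: the limit of > 20000 nM in this assay, at which 1 of the 4 values shown sits.

The compounds shown give only a floor for this step and no size for it, so how far the methyl moves the number remains unknown. They also leave open how an amine, a carboxylic acid or a longer chain such as propyl would read at this same place on the ring, and whether any of these would give a lower number than hydrogen does in compound 3.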